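The source may hold more compounds than are shown below. What is called first, only, known or untested is meant among the compounds shown, and "the series" means these compounds.

compound 1 `CCCC(C)C(=O)NCC(C)(C)CC1=C(O)C(=O)c2ccccc2C1=O`: 48100 nM
compound 2 `CCCCCCC(=O)NCC(C)(C)CC1=C(O)C(=O)c2ccccc2C1=O`: 24800 nM
compound 3 `CCCCCCCC(=O)NCC(C)(C)CC1=C(O)C(=O)c2ccccc2C1=O`: 18400 nM

These three values come from an ADME assay on Vero cells (Chlorocebus sabaeus) for cytotoxicity, read by reporter gene assay, with a stated time of 4 days; a higher number here means a weaker inhibitor, a lower number a stronger inhibitor. Compound 3 stands at 18400 nM, and two measured steps lead to it: a 2.6-fold lower number from compound 1 to compound 3 (0.42 log units; beyond the scatter) and a 1.3-fold lower number from compound 2 to compound 3 (0.13 log units; within the scatter).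

Compound 4 `CCCCCCC(C)C(=O)NCC(C)(C)CC1=C(O)C(=O)c2ccccc2C1=O` has not been measured. It carries methyl in place of hydrogen on a saturated chain carbon bound to a carbonyl carbon and a saturated chain carbon, so heptyl becomes 1-methylheptyl (methyl in place of hydrogen on a saturated chain carbon bound to a carbonyl carbon and a saturated chain carbon).

Within the data shown here, no measured step makes exactly this change. The closest is a 1.3-fold lower number from compound 2 to compound 3 (0.13 log units; within the scatter), which also puts methyl in place of hydrogen, but six bonds along the chain from a carbonyl carbon. Compound 1 does carry a 1-methyl chain, but its chain also differs in length, so a 1.9-fold lower number from compound 1 to compound 2 (0.29 log units; within the scatter) and a 2.6-fold lower number from compound 1 to compound 3 (0.42 log units; beyond the scatter) cannot isolate the methyl's contribution. The evidence therefore points to no clear change in this assay, and the expected step is a 1.2-fold lower number from compound 3 to compound 4 (0.06 log units; within the scatter), within the scatter.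

For compound 4 the estimated value is 16000 nM, with an expected range of 7500 nM to 34000 nM.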

Compound 4, half-maximal inhibitory concentration: 15500 nM
For compound 4 the middle estimate is 1.0-fold (0.01 log units) above the measured one; the measured number falls inside the stated range.
By their numbers in this assay, from the lowest: compounds 4, 3, 2 and 1 (each within the scatter of the next, the first and the last beyond it).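

In this assay, among these compounds, methyl in place of hydrogen on a saturated chain carbon bound to a carbonyl carbon gives a 1.2-fold lower number from compound 3 to compound 4 (0.07 log units; within the scatter) and so leaves no clear mark: heptyl and 1-methylheptyl read alike, the first view of this change on its own. With the methyl kept on that carbon, 1-methylbutyl and 1-methylheptyl do part, with a 3.1-fold lower number from compound 1 to compound 4 (0.49 log units; beyond the scatter) as a modest step, while the move from hexyl to 1-methylheptyl gives a 1.6-fold lower number from compound 2 to compound 4 (0.20 log units; within the scatter) and stays inside the noise. Nothing here accounts for these numbers.

From the compounds shown here alone, whether a hydroxyl, an amine or a carboxylic acid on the same carbon would shift the number remains open. So does the reading for a longer chain, such as 1-methyldecyl.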